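Bromo for Methyl on the Furan of Compound 3

This account rests on a few compounds, and the source may have more. Where it says the series, first, only, none or still open, it means among the compounds named here.

Of the compounds shown here, three have been measured in a functional assay on SMA cells (Homo sapiens) for inhibition, read by MTT assay, with a stated time of 72 h; a lower number here means a stronger inhibitor of growth, a higher number a weaker inhibitor of growth. Compound 1 `N#C/C(=C\c1ccc(Cl)cc1)C(=O)c1ccc[nH]1` gives 38000 nM. Compound 2 `COc1ccc(CNC(=O)/C(C#N)=C/c2ccco2)cc1` gives 33000 nM, and compound 3 `COc1ccc(CNC(=O)/C(C#N)=C/c2ccc(C)o2)cc1` gives 69000 nM in this assay. Compound 3 stands at the high end of these three values: its difference from compound 1 lies within the scatter, while the step of a 2.1-fold higher number from compound 2 to compound 3 (0.32 log units; beyond the scatter) lies beyond it, though it is modest.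

Compound 4 `COc1ccc(CNC(=O)/C(C#N)=C/c2ccc(Br)o2)cc1` differs from compound 3 by bromo in place of methyl on an aromatic carbon. Within the data shown here, no measured step exchanges one substituent for another at this site. Among the measured compounds shown here, the only step touching this site is a 2.1-fold higher number from compound 2 to compound 3 (0.32 log units; beyond the scatter), which introduced the methyl and was small in size. For the measured compounds named here, a bromo replacing that methyl has no measured precedent here, so nothing in the data points to a large move in either direction. The expected step of a 1.4-fold lower number from compound 3 to compound 4 (0.14 log units; within the scatter) is therefore estimated to stay within the scatter. The estimate for compound 4 in this assay is 50000 nM, with a range from 18000 nM to 140000 nM.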

Compound 4, concentration for 50% growth inhibition: 14000 nM
Estimate against measurement, compound 4: 3.6-fold (0.55 log units) above, outside the stated range (below it).
By their numbers in this assay, from the lowest: compound 4; then compounds 2, 1 and 3 (each within the scatter of the next, the first and the last beyond it).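

In this assay, among these compounds, the exchange of methyl for bromo on this aromatic carbon next to the ring oxygen gives a 4.9-fold lower number from compound 3 to compound 4 (0.69 log units; beyond the scatter), the first measured swap of one substituent for another at this site and a larger move than the earlier step that introduced the methyl. Measured against the hydrogen of compound 2, the two groups move the number in opposite directions: methyl gives a 2.1-fold higher number from compound 2 to compound 3 (0.32 log units; beyond the scatter), while bromo gives a 2.4-fold lower number from compound 2 to compound 4 (0.37 log units; beyond the scatter), so this position responds in both directions and not only to the loss of the methyl. No measured evidence here bears on why the two groups differ.

From the compounds shown here alone, whether chloro, iodo, an amine or a carboxylic acid at this carbon would follow bromo or methyl stays open. So does whether the bromo gain carries over to the core of compound 1.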